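Phenyl in place of propyl: cytotoxicity outlook for compound 3

A few compounds are considered here, and "the series" means these few. Any claim that something is new, unique, unknown or untested is made for them only; others in the source may bear on it.

Compound 2 `CCCc1cc2cn(C3CC(CO)N(C)O3)c(=O)nc2o1` carries a propyl on an aromatic carbon of the shared core. In an ADME assay on Vero cells (Chlorocebus sabaeus) for cytotoxicity, read by microscopy, with a stated time of 96 h (on this read-out lower numbers stand for higher toxicity in this test and higher numbers for lower toxicity in this test), compound 2 gives only a limit, > 500000 nM. Compound 1 `CN1OC(n2cc3ccoc3nc2=O)CC1CO`, which has hydrogen in place of that propyl, also gives only a limit in this assay, > 500000 nM. The step that the two limits leave unreadable from compound 1 to compound 2 therefore cannot be read, since (the limit of > 500000 nM in this assay, at which 2 of the 2 values shown sit). Among the measured compounds shown here, compound 2 thus stands at the limit of the assay, and the one further value shown is also a limit.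

Compound 3 `CN1OC(n2cc3cc(-c4ccccc4)oc3nc2=O)CC1CO` is the next variation: phenyl in place of propyl on an aromatic carbon. For the measured compounds named here, the only measured step bearing on this change, a step that the two limits leave unreadable from compound 1 to compound 2, is unreadable, so no measured size is available for it; what is known is that both measured compounds sit at the limit. The expectation for this assay is accordingly no step beyond the scatter, with compound 3 most likely returning only a limit again. Compound 3 is estimated at 500000 nM, with a range from 150000 nM to 1000000 nM. The expected step of a number no higher from compound 2 to compound 3 (the limit leaves the size open) is essentially none.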

Compound 3, minimum cytotoxic concentration: 125000 nM
Estimate against measurement, compound 3: 4.0-fold (0.60 log units) above; measured number below the stated range.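

In this assay, the aromatic carbon next to the ring oxygen now gives a readable response: phenyl in place of propyl gives an at least 4.0-fold lower number from compound 2 to compound 3 (0.60 log units; beyond the scatter), and phenyl in place of hydrogen gives an at least 4.0-fold lower number from compound 1 to compound 3 (0.60 log units; beyond the scatter). This position therefore does not leave the read-out at the limit with every group, and among the compounds shown only compound 3, with its six-membered aromatic ring of carbon only, has a measured number, on the side of higher toxicity in this test. Both steps remain open-ended in size because each starts from a compound at a limit: the limit of > 500000 nM in this assay, at which 2 of the 3 values shown sit.

The step from hydrogen to propyl cannot be read, so the compounds shown do not tell how far either compound 1 or compound 2 lies from compound 3, nor whether the shift follows the aromatic ring or simply the larger group. A longer chain such as octyl at this position would bear on that second question, and a phenyl carrying an amine or a carboxylic acid would show whether the read-out at this position also responds to substitution on the ring.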